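Working notes: from compound 3 to compound 4

This account rests on a few compounds, and the source may have more. Where it says the series, first, only, none or still open, it means among the compounds named here.

Values in an ADME assay on HEK293 cells (Homo sapiens) for cytotoxicity, read by CCK-8 assay, with a stated time of 48 h; a higher number here means a weaker inhibitor, a lower number a stronger inhibitor:
- compound 1 `COc1ccc(/C=C\c2cc(OC)c(OC)c(OC)c2)cc1OCc1ccc(CNC(C)(C)C(=O)O)cc1`: > 50000 nM (a limit)
- compound 2 `COc1ccc(/C=C\c2cc(OC)c(OC)c(OC)c2)cc1OCc1ccc(CN2CCCCC2C(=O)O)cc1`: > 50000 nM (a limit)
- compound 3 `COc1ccc(/C=C\c2cc(OC)c(OC)c(OC)c2)cc1OCc1ccc(CN[C@H](C(=O)O)[C@H](C)O)cc1`: > 50000 nM (a limit)

Compound 3 stands at > 50000 nM in this assay, and this is a limit, not a number. Among the compounds with values here, the series so far rests on (the limit of > 50000 nM in this assay, at which 3 of the 3 values shown sit), so no order among the three compounds can be read.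

The next compound is compound 4 `COc1ccc(/C=C\c2cc(OC)c(OC)c(OC)c2)cc1OCc1ccc(CN2CC[C@H](C(=O)O)C2)cc1`, and its difference from compound 3 is counted as 3-carboxypyrrolidin-1-yl in place of (1-carboxy-2-hydroxypropyl)amino on a saturated chain carbon bound to an aromatic carbon. In words, 3-carboxypyrrolidin-1-yl comes in place of (1-carboxy-2-hydroxypropyl)amino on a saturated chain carbon bound to an aromatic carbon.

The closest measured change is a step that the two limits leave unreadable from compound 2 to compound 3, which concerns the same place. The other two are a step that the two limits leave unreadable from compound 1 to compound 2 and a step that the two limits leave unreadable from compound 1 to compound 3, and none of the three has a readable size. Compound 2 carries a ring-bearing group in the same place and gives > 50000 nM, again a limit.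

With no readable step to go on, the step expected in this assay is a number no higher from compound 3 to compound 4 (the limit leaves the size open), with no direction expected beyond the scatter. For compound 4 the estimated value is 50000 nM, expected to lie in the range from 25000 nM to 100000 nM, and most likely to be reported as a limit again.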

Compound 4, half-maximal inhibitory concentration: > 50000 nM
Compound 4: a limit, no number (the forecaster's own chance of this, stated with the estimate: 85%); the middle value sits exactly at the limit.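

In this assay compound 4 gives > 50000 nM, which is a limit and not a number. Within the data shown here, no new step among compound 1, compound 2, compound 3 and compound 4 can be read. The compounds shown leave open whether any group on a saturated chain carbon bound to an aromatic carbon changes the value, and the series still rests on a single limit: the limit of > 50000 nM in this assay, at which 4 of the 4 values shown sit.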